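The source may report more compounds than this note shows. Statements on the series, on what has been measured and on what is new or still open speak of the compounds shown alone.

Measured compounds:
compound 1 `CCCCc1cn(C(c2ccccc2)c2cc3cc(Br)ccc3nc2OC)nn1` — 11.1%
compound 2 `CCCCCCCc1cn(C(c2ccccc2)c2cc3cc(Br)ccc3nc2OC)nn1` — 10.5%
compound 3 `COc1nc2ccc(Br)cc2cc1C(c1ccccc1)n1cc(-c2ccc(F)cc2)nn1` — 14.3%

All three were run in an ADME assay on SK-OV-3 cells (Homo sapiens) for cytotoxicity, read by sulforhodamine B assay, with a stated time of 48 h, tested at 10 uM; on this read-out higher numbers stand for more inhibition at the one concentration tested (going by the name of the read-out) and lower numbers for less inhibition. On these numbers compound 1 stands second highest of three; its nearest neighbour is compound 2 with a number 0.6 percentage points lower from compound 1 to compound 2 (within the scatter), its furthest is compound 3 with a number 3.2 percentage points higher from compound 1 to compound 3 (within the scatter). Neither separation exceeds the scatter, so the three compounds cannot be ordered.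

Compound 4 `COc1nc2ccc(Br)cc2cc1C(c1ccccc1)n1cc(CCO)nn1` is not yet measured in this assay. It differs from compound 1 by hydroxy in place of ethyl on a saturated chain carbon, two bonds along the chain from an aromatic carbon. Among the measured compounds shown here, no measured step exchanges part of this chain for a hydroxy group, so the bearing is indirect. The steps that touch the same position of the shared core are a number 0.6 percentage points lower from compound 1 to compound 2 (within the scatter), a number 3.2 percentage points higher from compound 1 to compound 3 (within the scatter) and a number 3.8 percentage points higher from compound 2 to compound 3 (within the scatter); every one of them lies within the scatter, whether a chain is lengthened or replaced by 4-fluorophenyl. Variation at this position has so far produced nothing beyond the scatter, and no step in the set suggests compound 4 should behave otherwise.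

The expectation for compound 4 is therefore a step of a number 0.1 percentage points lower from compound 1 to compound 4 (within the scatter), none beyond the scatter. Compound 4 is estimated at 11%, with a range from 2% to 21%.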

Compound 4, a percentage reported as inhibition, at one concentration (the size of the read-out at that concentration, not a potency): 8.46%
Beside the measured number, compound 4's estimate is 2.5 percentage points above it, and the stated range covers the measured number.
By their numbers in this assay, from the lowest: compounds 4, 2, 1 and 3 (each within the scatter of the next).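

In this assay, the change from butyl to 2-hydroxyethyl introduces the hydrogen-bond donor and acceptor counted for hydroxy, and it gives a number 2.6 percentage points lower from compound 1 to compound 4 (within the scatter); the other two new steps are a number 2 percentage points lower from compound 2 to compound 4 (within the scatter) and a number 5.8 percentage points lower from compound 3 to compound 4 (within the scatter). The earlier compounds shown here covered only alkyl chains and 4-fluorophenyl at this position, whereas the series now includes a chain ending in hydroxy, and all four compounds still remain inseparable on this read-out. The available data offer no explanation for these numbers.

From the compounds shown here alone, whether any group at this position can produce a step beyond the scatter remains open, and a primary amine or a carboxylic acid at the end of the chain, or a longer chain ending in hydroxy, would test this further. The read-out also reports inhibition at a single concentration, so the compounds shown leave open whether potencies would separate them, and whether the same flat picture holds when the shared core is changed rather than this chain.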